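This account rests on a few compounds, and the source may have more. Where it says the series, first, only, none or still open, it means among the compounds named here.

Measured compounds in an assay on COS-7 cells for inhibition of patatin-like phospholipase domain-containing protein 2 (Mus musculus), tested at 200 uM; on this read-out higher numbers stand for more inhibition at the one concentration tested (going by the name of the read-out) and lower numbers for less inhibition:

- compound 1 `CCOC(=O)c1cncc(-c2ccc(OCC)cc2)c1` gives 70%
- compound 2 `CCOC(=O)c1cccc(-c2ccc(OCC)c(N)c2)c1` gives 59%
- compound 3 `CCOc1ccc(-c2cccc(S(=O)(=O)N(C)C)c2)cc1` gives 63%

The three numbers from this assay all lie within the usual scatter of one another, so compound 3 is not separated from either neighbour: its nearest value is that of compound 2, a few points lower, and the furthest is that of compound 1, a few points higher, both gaps inside the scatter. Among the compounds with values here, no pair among the measured compounds differs in only one place, so no isolated step is available to read a trend from.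

Compound 4 `CCOc1ccc(-c2cccc(NC(=O)N(C)C)c2)cc1` is the next compound to go into this assay. It differs from compound 3 in one place: (dimethylcarbamoyl)amino in place of dimethylsulfamoyl on an aromatic carbon. Within the data shown here, the series so far gives no pair that tests this exchange, so the expectation rests only on the narrow band of the three measured values. The step from compound 3 to compound 4 in this assay is expected to be small, most likely none beyond the scatter, with a slight downward lean as the more probable direction if any; this is the estimated a number 5 percentage points lower from compound 3 to compound 4 (within the scatter). For compound 4 the expected value in this assay is 58%, in a range from 35% to 78%.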

Compound 4, a percentage reported as inhibition, at one concentration (the size of the read-out at that concentration, not a potency): 68%
Compound 4: the middle estimate sits 10 percentage points below what was measured, within the range that was stated.
By their numbers in this assay, from the lowest: compounds 2, 3, 4 and 1 (each within the scatter of the next, the first and the last beyond it).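

In this assay, within the data shown here, the exchange of dimethylsulfamoyl for (dimethylcarbamoyl)amino on an aromatic carbon gives a number 5 percentage points higher from compound 3 to compound 4 (within the scatter) and is the only single-place step so far. At this position the read-out does not separate the two groups, although the entering group carries a hydrogen-bond donor that the leaving group lacks and has one double bond fewer outside aromatic rings. Nothing measured here explains this result.

Still open, as far as these compounds go, is whether any group at this position can move the number beyond the scatter, and a primary amine or a carboxylic acid on the same aromatic carbon would test that. Also open, from the compounds shown here alone, is whether this same exchange reads alike when the rest of the molecule differs, as it does in compound 1 and compound 2.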